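Aminothiophene ketones at the A3 receptor: a null series

The source may report more compounds than this note shows. Statements on the series, on what has been measured and on what is new or still open speak of the compounds shown alone.

Measured so far:
- Compound 1, `Cc1ccc(C(=O)c2c(CC(C)(C)C)csc2N)cc1`: 1%
- Compound 2, `COc1ccc(-c2sc(N)c(C(=O)c3cccc(Cl)c3)c2CC(C)(C)C)cc1`: 2%

In an assay on CHO cells for displacement of a labelled ligand from adenosine receptor A3 (Homo sapiens), read by scintillation counting, tested at 10 uM (on this read-out lower numbers stand for less inhibition and higher numbers for more inhibition at the one concentration tested (going by the name of the read-out)), compound 1 gives 1% and compound 2 gives 2%. Compound 2 stands at the higher of the two numbers, but the gap to compound 1 lies within the scatter, so neither compound is separated from the other, and both sit at the floor of the read-out.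

Compound 3, `COc1ccc(-c2sc(N)c(C(=O)c3ccc(C)cc3)c2CC(C)(C)C)cc1`, is not yet measured. Compared with compound 2 the change is 4-methylphenyl in place of 3-chlorophenyl on a carbonyl carbon. Compound 1 already carries a 4-methylphenyl on its carbonyl carbon and gives no inhibition worth noting, so nothing among the numbers in hand argues for a rise. The step of no change at the digits printed from compound 2 to compound 3 (within the scatter) is expected to be none beyond the scatter. Compound 3 is expected to give 2%, between 0% and 12%.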

Compound 3, a percentage reported as inhibition, at one concentration (the size of the read-out at that concentration, not a potency): 5%
Compound 3: middle estimate off by 3 percentage points, on the low side; low and high end bracket the measured number.
By their numbers in this assay, from the lowest: compounds 1, 2 and 3 (each within the scatter of the next).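

Going by these compounds alone, compound 1 and compound 2 differ in more than one place, so these are the first single-place comparisons. With 4-methylphenyl in place of 3-chlorophenyl on a carbonyl carbon, this assay shows a number 3 percentage points higher from compound 2 to compound 3 (within the scatter), so this exchange of aryl groups does not separate the two ketones. With 4-methoxyphenyl in place of hydrogen on an aromatic carbon, the same read-out shows a number 4 percentage points higher from compound 1 to compound 3 (within the scatter), so that aromatic carbon gives no separation either, and no measurement in hand offers an explanation for these flat numbers.

Still open, as far as these compounds go, is whether a non-aryl group on the carbonyl carbon, such as a cyclohexyl ring or a chain ending in an amine, would give a number beyond the scatter. Also open, from the compounds shown here alone, is whether a carboxylic acid on the 4-methoxyphenyl ring would do so.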